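Glycine transporter series: dichlorophenyl amide on the fused core

A few compounds are considered here, and "the series" means these few. Any claim that something is new, unique, unknown or untested is made for them only; others in the source may bear on it.

Measured compounds:
compound 1, `CCS(=O)(=O)N1CC2CCC(NC(=O)c3ccc(Cl)cc3Cl)C2C1` — > 10000 nM
compound 2, `Cn1cnc(S(=O)(=O)N2CC3CCC(NC(=O)c4ccccc4F)C3C2)c1` — 1820000 nM

In an assay on isolated protein for inhibition of sodium- and chloride-dependent glycine transporter 1 (Homo sapiens) (a lower number here means a stronger inhibitor, a higher number a weaker inhibitor), compound 2 gives 1820000 nM. For compound 1 the readout is a limit of the assay, (the limit of > 10000 nM in this assay, at which 1 of the 2 values shown sits), and no number is reported. Going by the values given here, compound 2 is therefore the only compound of the two with a numerical value, and that value is very weak; no measured step between the two compounds is available, and their shared core is the same bicyclic amine carrying a sulfonyl group and an amide.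

Compound 3, `Cn1cnc(S(=O)(=O)N2CC3CCC(NC(=O)c4ccc(Cl)c(Cl)c4)C3C2)c1`, is not yet measured. It differs from compound 2 in one place: 3,4-dichlorophenyl in place of 2-fluorophenyl on a carbonyl carbon. With no measured step of this kind in the series, the direction cannot be read from the data; the expectation is a moderate gain in this assay, well beyond the scatter but with wide uncertainty. Compound 3 is expected to give 200000 nM, in a range from 20000 nM to 2000000 nM. The estimated step of a 9.1-fold lower number from compound 2 to compound 3 (0.96 log units; beyond the scatter) is the basis of that expectation.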

Compound 3, half-maximal inhibitory concentration: 891000 nM
For compound 3 the middle estimate is 4.5-fold (0.65 log units) below the measured one; low and high end bracket the measured number.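

In this assay, 3,4-dichlorophenyl in place of 2-fluorophenyl on a carbonyl carbon gives a 2.0-fold lower number from compound 2 to compound 3 (0.31 log units; beyond the scatter), the only measured step shown in the series. The position on the carbonyl carbon therefore responds to a change of aryl group, with the sulfonyl side and the shared core unchanged, yet the step is modest and compound 3 remains a very weak inhibitor at 891000 nM in this assay. Nothing in the data shown gives a reason for this step.

A single exchange removes the fluorine and introduces both chlorine atoms, so the share of each remains unresolved, as does the response to other groups on that carbonyl carbon, such as a pyridine ring, an aminophenyl group or a benzoic acid. Compound 1 gives only a limit of the assay, > 10000 nM, and differs from the other compounds in more than one place, so the effect of its ethyl sulfonyl group cannot be read.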